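The compounds below may be only part of what the source reports. "The series", "measured", "known", "first", "only" and "open" are said of these compounds alone.

For the measured compounds named here, in a functional assay on HT-29 cells (Homo sapiens) for inhibition, read by MTT assay, with a stated time of 48 h (a lower number here means a stronger inhibitor, a higher number a weaker inhibitor), compound 2 `COc1cc(-c2cc(-c3ccccc3)nc(-c3ccccc3)n2)cc(OC)c1OC` gives 7930 nM as the only actual number so far. Compound 1 `COc1cc(-c2cc(-c3cccc(O)c3)nc(-c3ccccc3)n2)cc(OC)c1OC` reads > 25000 nM and that value is a limit of the assay. Going by the values given here, the one measured step of an at least 3.1-fold lower number from compound 1 to compound 2 (0.49 log units; beyond the scatter) is hydrogen in place of hydroxy on an aromatic carbon. Compound 3 `COc1cc(-c2cc(-c3ccc(O)cc3O)nc(-c3ccccc3)n2)cc(OC)c1OC` carries 2,4-dihydroxyphenyl in place of phenyl on an aromatic carbon and so brings hydroxy back. Among the compounds with values here, with only the step of an at least 3.1-fold lower number from compound 1 to compound 2 (0.49 log units; beyond the scatter) to go on, a move of similar size toward a higher number is expected in this assay for this change. The expected step of a 2.3-fold higher number from compound 2 to compound 3 (0.36 log units; beyond the scatter) is an estimate only. Compound 3 is estimated at 18000 nM with an expected range from 6000 nM to 50000 nM in this assay.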

Compound 3, half-maximal inhibitory concentration: 4960 nM
The estimate for compound 3 lay 3.6-fold (0.56 log units) above the measured number; the measured number lies below the stated range.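

In this assay, hydroxy at this place does not by itself bring the loss that the earlier step suggested: 2,4-dihydroxyphenyl in place of phenyl gives a 1.6-fold lower number from compound 2 to compound 3 (0.20 log units; within the scatter). Set against 3-hydroxyphenyl, the same group gives an at least 5.0-fold lower number from compound 1 to compound 3 (0.70 log units; beyond the scatter), so among these compounds the outcome follows the hydroxy pattern and not the mere presence of hydroxy. Compound 1 stands at a limit, so that step is a bound only: the limit of > 25000 nM in this assay, at which 1 of the 3 values shown sits.

On these data alone, whether 2-hydroxyphenyl or 4-hydroxyphenyl alone would read like compound 3 stays open, as does the reading with 2,4-dimethoxyphenyl or an aminophenyl group at this place.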